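Carbamate ester variations on a shared core

The source may report more compounds than this note shows. Statements on the series, on what has been measured and on what is new or still open speak of the compounds shown alone.

Measured compounds:
compound 1, `Cc1nc(S(C)(=O)=O)ccc1Oc1ncnc(OC2CCN(C(=O)OC3CCC3)CC2)c1F`, 13.6 nM
compound 2, `Cc1nc(S(C)(=O)=O)ccc1Oc1ncnc(OC2CCN(C(=O)O[C@H](C)C(F)(F)F)CC2)c1F`, 9.2 nM
compound 3, `CCC1(OC(=O)N2CCC(Oc3ncnc(Oc4ccc(S(C)(=O)=O)nc4C)c3F)CC2)CC1`, 22 nM

The three compounds differ only in the group on an oxygen next to a carbonyl group and were all read in a functional assay on isolated protein for inhibition of Glucose-dependent insulinotropic receptor (Homo sapiens), read by HTRF and cAMP accumulation; a higher number here means that more compound is needed for the effect, a lower number that less compound is needed. Compound 1 stands second highest of the three numbers; the nearest is compound 2 with a 1.5-fold lower number from compound 1 to compound 2 (0.17 log units; within the scatter), the furthest compound 3 with a 1.6-fold higher number from compound 1 to compound 3 (0.21 log units; within the scatter). Going by the values given here, only the step of a 2.4-fold higher number from compound 2 to compound 3 (0.38 log units; beyond the scatter) reaches beyond the scatter, and it is modest.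

Compound 4, `Cc1nc(S(C)(=O)=O)ccc1Oc1ncnc(OC2CCN(C(=O)OC3COC3)CC2)c1F`, is not yet measured. Against compound 1 it carries oxetan-3-yl in place of cyclobutyl on an oxygen next to a carbonyl group. Among the compounds with values here, the steps that bear on this are the two from compound 1, to compound 2 and to compound 3, both within the scatter, so changes of this group at this position have so far moved the number little. The step of a 1.3-fold higher number from compound 1 to compound 4 (0.10 log units; within the scatter) is therefore expected to stay within the scatter, if anything toward a slightly higher number. For compound 4 the estimate is 17 nM, with a range from 8 nM to 36 nM.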

Compound 4, half-maximal effective concentration: 326 nM
Compound 4: middle estimate off by 19-fold (1.28 log units), on the low side, and the stated range ends below it.
By their numbers in this assay, from the lowest: compounds 2, 1 and 3 (each within the scatter of the next, the first and the last beyond it); then compound 4.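

In this assay the group on this oxygen proves far less forgiving than the earlier esters suggested: oxetan-3-yl gives a 24-fold higher number from compound 1 to compound 4 (1.38 log units; beyond the scatter) and also stands well apart from the other two, with a 15-fold higher number from compound 3 to compound 4 (1.17 log units; beyond the scatter) and a 35-fold higher number from compound 2 to compound 4 (1.55 log units; beyond the scatter) as the matching steps. Cyclobutyl and oxetan-3-yl have the same number of heavy atoms and the same ring size, and differ in one ring carbon exchanged for oxygen, which adds a hydrogen-bond acceptor, yet this exchange gives a large step where the earlier changes between cyclobutyl, 1-(trifluoromethyl)ethyl and 1-ethylcyclopropyl gave little or modest ones. No measurement at hand accounts for this step.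

On these data alone, it remains open whether the large step belongs to oxygen in particular or to any hetero atom in this ring, which an azetidin-3-yl or thietan-3-yl group would test. Also open, as far as these compounds go, is whether an oxygen in an open chain, as in a 2-methoxyethyl group, behaves in the same way.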